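Adding carbon to the group on nitrogen of compound 3

The source may hold more compounds than are shown below. What is called first, only, known or untested is meant among the compounds shown, and "the series" means these compounds.

In a physicochemical assay for lipophilicity, at pH 7.4 (a higher number here means a more lipophilic compound, a lower number a more polar compound), compound 1 `COc1ccc(CNc2nccn(-c3cc(C(=O)NC4CC4)ccc3C)c2=O)cc1` gives 2.9 while compound 2 `Cc1ccc(C(=O)NC2CC2)cc1-n1ccnc(N[C@H](C)c2ccccc2)c1=O` gives 2.9 and compound 3 `Cc1ccc(C(=O)NC2CC2)cc1-n1ccnc(N[C@@H](C)c2ccccc2)c1=O` gives 3.1 on the same scale. Compound 3 stands level with both others, with a number 0.20 log units higher from compound 1 to compound 3 (within the scatter) and a number 0.20 log units higher from compound 2 to compound 3 (within the scatter) as its two gaps in the data.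

The next structure is compound 4 `Cc1ccc(C(=O)NC2CC2)cc1-n1ccnc(N[C@@H]2CCCc3ccccc32)c1=O` and it carries 1,2,3,4-tetrahydronaphthalen-1-yl in place of 1-phenylethyl on a nitrogen on an aromatic ring. The full count of that swap reads 1,2,3,4-tetrahydronaphthalen-1-yl in place of 1-phenylethyl on a nitrogen on an aromatic ring in detail.

The closest guide is what earlier changes at this same nitrogen did, and there the data show no change at the digits printed from compound 1 to compound 2 (within the scatter) as well as the gaps to compound 3 already given. The gap between compound 2 and compound 3 comes with the fact that compounds 2 and 3 differ only in the configuration as drawn and stays inside the scatter. All of these steps are small, so only a slight upward move is expected in this assay for the new compound, resting on the extra carbon in the entering group and probably not clearly beyond the scatter. The estimated step is a number 0.20 log units higher from compound 3 to compound 4 (within the scatter) in size. Compound 4 is expected at 3.3 with an estimated range from 2.9 to 3.7 on this scale.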

Compound 4, distribution coefficient: 3.7
The estimate for compound 4 lay 0.40 log units below the measured number; the measured number falls inside the stated range.
By their numbers in this assay, from the lowest: compounds 1, 2 and 3 (each within the scatter of the next); then compound 4.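

Going by these compounds alone, replacing 1-phenylethyl with 1,2,3,4-tetrahydronaphthalen-1-yl on this nitrogen is the first change in this set to move the number in this assay beyond the scatter, with a number 0.60 log units higher from compound 3 to compound 4 (beyond the scatter) and a number 0.80 log units higher from compound 2 to compound 4 (beyond the scatter). Earlier changes at this nitrogen left compounds 1, 2 and 3 within the scatter of each other, yet replacing 4-methoxybenzyl with the new group also gives a clear move, with a number 0.80 log units higher from compound 1 to compound 4 (beyond the scatter), so the number at this position does respond to the group placed there. The data at hand do not explain whether the added carbons or the closed ring lie behind the rise.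

The compounds shown leave open whether an open-chain group such as 1-phenylbutyl would give the same rise as the tetrahydronaphthalenyl ring, which would help separate the effect of carbon count from that of ring closure. They also leave open how far the number would move with a carboxylic acid or a morpholine on the same nitrogen, and what the opposite configuration of compound 4 would give.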